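This account rests on a few compounds, and the source may have more. Where it says the series, first, only, none or still open, it means among the compounds named here.

Measured compounds:
- compound 1 `COc1ccc(/C=C/C(=O)/C=C/C2=C(C)CCCC2(C)C)cc1`: in a functional assay on PC-3 cells (Homo sapiens) for cytotoxicity, read by sulforhodamine B assay, with a stated time of 48 h (a higher number here means a weaker inhibitor, a lower number a stronger inhibitor), compound 1 gives 58700 nM
- compound 2 `CC1=C(/C=C/C(=O)/C=C/c2ccc([N+](=O)[O-])cc2)C(C)(C)CCC1`: in this assay compound 2 gives 1900 nM

Compound 1 stands at the highest of the two numbers; its nearest neighbour is compound 2, reached by a 31-fold lower number from compound 1 to compound 2 (1.49 log units; beyond the scatter), a change of nitro in place of methoxy on an aromatic carbon. Compound 3 `COc1ccc(/C=C/C(=O)/C=C/C2=C(C)CCCC2(C)C)cc1OC` keeps the core of compound 1 and differs only by methoxy in place of hydrogen on an aromatic carbon, ortho to a methoxy group and meta to a large group. For the measured compounds named here, the single measured step shows that swapping the aromatic substituent can move this assay a long way, but it concerns a different exchange, so it gives little direct guidance for adding a methoxy next to the existing one. Going by the values given here, with only that indirect evidence, the change from compound 1 to compound 3 is expected to lie within the scatter, estimated as a 1.5-fold lower number from compound 1 to compound 3 (0.17 log units; within the scatter). Compound 3 is therefore estimated at 40000 nM, within a range of 12000 nM to 120000 nM.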

Compound 3, half-maximal inhibitory concentration: 30200 nM
For compound 3 the middle estimate is 1.3-fold (0.12 log units) above the measured one, and the stated range covers the measured number.
By their numbers in this assay, from the lowest: compound 2; then compounds 3 and 1 (each within the scatter of the next).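

Placing methoxy in place of hydrogen on an aromatic carbon, ortho to a methoxy group and meta to a large group, gives in this assay a 1.9-fold lower number from compound 1 to compound 3 (0.29 log units; within the scatter), so compound 3 cannot be told apart from compound 1 here. The earlier step, a 31-fold lower number from compound 1 to compound 2 (1.49 log units; beyond the scatter), exchanged the existing methoxy for nitro, whereas this change adds a group at a carbon that carries hydrogen in compound 1, and at this carbon methoxy produces no step beyond the scatter. No measurement at hand speaks to the reason for this result.

Going by these compounds, whether a hydroxyl, an amine or a chlorine atom on this same carbon would read differently from hydrogen remains open. Also open, on these data alone, is whether nitro, combined with a methoxy at this carbon, would keep the number seen for compound 2.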